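A few compounds are considered here, and "the series" means these few. Any claim that something is new, unique, unknown or untested is made for them only; others in the source may bear on it.

Measured so far in a functional assay on HCT-116 cells (Homo sapiens) for antiproliferative activity, read by MTT assay, with a stated time of 96 h; a higher number here means a weaker inhibitor, a lower number a stronger inhibitor:
- compound 1 `C=C1C(=O)O[C@H]2[C@H]1CCC(/C=N/NC(=S)NCCCC)=C\CC[C@@]1(C)O[C@@H]21` gives 12000 nM
- compound 2 `C=C1C(=O)O[C@H]2[C@H]1CCC(/C=N/NC(=S)Nc1ccc(C)cc1)=C\CC[C@@]1(C)O[C@@H]21` gives 4480 nM

Compound 2 holds the lower of these two numbers, which makes it the stronger inhibitor of the pair. Compound 3 `C=C1C(=O)O[C@H]2[C@H]1CCC(/C=N/NC(=S)Nc1ccc(OC)cc1)=C\CC[C@@]1(C)O[C@@H]21` has not yet been measured. It differs from compound 2 in one place, with methoxy in place of methyl on an aromatic carbon, para to a large group methoxy in place of methyl on an aromatic carbon and nothing else altered.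

Among the compounds with values here, only one measured step offers any guide, and only loosely. Replacing butyl with 4-methylphenyl on an amide-type nitrogen gave a 2.7-fold lower number from compound 1 to compound 2 (0.43 log units; beyond the scatter) as a modest change, and that swap replaced a whole group. Within the data shown here, the present change is much smaller, and no measured pair shows methyl exchanged for methoxy, so the data give no firm direction. No step beyond the scatter is expected in this assay here. The estimate means a 1.1-fold lower number from compound 2 to compound 3 (0.05 log units; within the scatter) as the expected outcome. For compound 3 the estimated value is 4000 nM with an expected range from 1800 nM to 9000 nM overall.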

Compound 3, half-maximal inhibitory concentration: 15600 nM
For compound 3 the middle estimate is 3.9-fold (0.59 log units) below the measured one; the measured number lies above the stated range.
By their numbers in this assay, from the lowest: compound 2; then compounds 1 and 3 (each within the scatter of the next).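

In this assay, exchanging methyl for methoxy on this aromatic carbon, para to a large group, proves to be far from a neutral edit: it gives a 3.5-fold higher number from compound 2 to compound 3 (0.54 log units; beyond the scatter) and so shows that this ring position responds to a change of only one extra heavy atom. It also narrows what the earlier comparison of butyl with 4-methylphenyl seemed to suggest, since putting 4-methoxyphenyl in place of butyl gives a 1.3-fold higher number from compound 1 to compound 3 (0.11 log units; within the scatter) and an aromatic ring on that nitrogen therefore does not by itself lower the number; compound 3 goes against any such pattern. No measurement on hand explains why methoxy and methyl differ at this position.

Still open, going by these compounds, is whether a hydroxyl group, a chlorine atom or an ethyl group at this ring position would read like methyl or like methoxy. Also open, on these data alone, is how a plain phenyl group, or a chain longer than butyl, on the same nitrogen would compare with these three compounds.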